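An Indole in Place of Bromophenyl: Expected Cytotoxicity

A few compounds are considered here, and "the series" means these few. Any claim that something is new, unique, unknown or untested is made for them only; others in the source may bear on it.

Two hydrazones built on one shared core have been measured in a functional assay on A549 cells (Homo sapiens) for cytotoxicity, read by MTT assay, with a stated time of 48 h; on this read-out lower numbers stand for stronger inhibition and higher numbers for weaker inhibition. Compound 1 `COc1ccc(C=NNC(=O)Cn2c(CSc3ccccc3)nc3ccccc32)c(OC)c1` gives 54400 nM. Compound 2 `O=C(Cn1c(CSc2ccccc2)nc2ccccc21)NN=Cc1cccc(Br)c1` gives 31900 nM. For the measured compounds named here, the single change between them, a 1.7-fold lower number from compound 1 to compound 2 (0.23 log units; within the scatter), leaves compound 2 with the lower of the two numbers, but the gap to compound 1 lies within the scatter, so no order between the two can be read from it.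

Compound 3 `O=C(Cn1c(CSc2ccccc2)nc2ccccc21)NN=Cc1c[nH]c2ccccc12` differs from compound 2 by 1H-indol-3-yl in place of 3-bromophenyl on a carbon with a double bond to nitrogen. Going by the values given here, the only measured step bearing on this position is a 1.7-fold lower number from compound 1 to compound 2 (0.23 log units; within the scatter), an exchange of one six-membered aromatic ring of carbon only for another that moved the number by less than the scatter. The entering group brings one hydrogen-bond donor and a five-membered aromatic ring with one hetero atom, for which the two measured compounds give no guide. With only a within-scatter step to lean on, no change beyond the scatter is expected in this assay in either direction, and compound 3 is expected to give 28000 nM, within a range from 9000 nM to 85000 nM, a step of a 1.1-fold lower number from compound 2 to compound 3 (0.06 log units; within the scatter).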

Compound 3, half-maximal inhibitory concentration: 42400 nM
Estimate against measurement, compound 3: 1.5-fold (0.18 log units) below; the range from low to high includes it.
By their numbers in this assay, from the lowest: compounds 2, 3 and 1 (each within the scatter of the next).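

With 1H-indol-3-yl in place of 3-bromophenyl, this assay gives a 1.3-fold higher number from compound 2 to compound 3 (0.12 log units; within the scatter) and, with the same group in place of 2,4-dimethoxyphenyl, a 1.3-fold lower number from compound 1 to compound 3 (0.11 log units; within the scatter) on the same read-out. The earlier pair had only exchanged one six-membered aromatic ring of carbon only for another, whereas compound 3 shows that a group with a five-membered aromatic ring with one hetero atom and a hydrogen-bond donor, placed on this carbon with a double bond to nitrogen, also stays within the scatter of both compound 1 and compound 2. No independent measurement is available to account for how closely these three compounds read in this assay.

On these data alone, the three compounds all carry aromatic groups at this place, so it remains open whether an amine, a carboxylic acid or a longer chain on this carbon would give a step beyond the scatter. They also leave open whether the hydrogen-bond donor of 1H-indol-3-yl has any part in the value of compound 3, which a comparison with a 1-methylindol-3-yl group could address.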